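This account rests on a few compounds, and the source may have more. Where it says the series, first, only, none or still open, it means among the compounds named here.

Compound 2 `CC(C)c1cc[n+]([O-])cc1Oc1ccccc1` gives the lower of the two numbers measured in a functional assay on the whole organism with Mus musculus as the target, in the maximal electroshock model, with a stated time of 30 min; a higher number here means that more compound is needed for the effect, a lower number that less compound is needed: compound 2 gives 30 mg/kg, while compound 1 `[O-][n+]1ccc(CO)c(Oc2ccccc2)c1` gives 300 mg/kg. Within the data shown here, the single measured step, a 10-fold lower number from compound 1 to compound 2 (1.00 log units; beyond the scatter), favours compound 2. Compound 3 `CC(C)(C)c1cc[n+]([O-])cc1Oc1ccccc1` differs from compound 2 by methyl in place of hydrogen on a saturated chain carbon bound to an aromatic carbon and two saturated chain carbons so that, cut one bond further out, isopropyl becomes tert-butyl. Among the measured compounds shown here, only the step from compound 1 to compound 2 bears on this, and it exchanged a different group entirely, so no shift beyond the scatter is expected. Compound 3 is therefore expected to give 30 mg/kg, between 10 mg/kg and 100 mg/kg, an expected step of no change at the digits printed from compound 2 to compound 3 (within the scatter).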

Compound 3, minimum effective dose: 30 mg/kg
Beside the measured number, compound 3's estimate shows no gap at the digits printed; measured number inside the range.
By their numbers in this assay, from the lowest: compounds 2 and 3 (each within the scatter of the next); then compound 1.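

In this assay there is no change at the digits printed from compound 2 to compound 3 (within the scatter) when methyl replaces hydrogen on the saturated chain carbon bound to an aromatic carbon and two saturated chain carbons, turning isopropyl into tert-butyl. With tert-butyl in place of hydroxymethyl there is a 10-fold lower number from compound 1 to compound 3 (1.00 log units; beyond the scatter) in the same direction as the step with isopropyl, so the extra methyl keeps the lower number. No measured evidence explains either step.

On these data alone, whether ethyl or an amine in place of these groups keeps the number this low remains open, as does whether any other group can take it lower than compounds 2 and 3.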